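The source may hold more compounds than are shown below. What is called first, only, known or untested is meant among the compounds shown, and "the series" means these compounds.

Measured compounds:
compound 1 `CN(C[C@H]1Cc2c(cccc2N2CCN(C3COC3)CC2)CN1)[C@H]1CCCc2cccnc21`: 50.8%
compound 2 `C[C@@H]1CN(c2cccc3c2C[C@H](CN(C)[C@H]2CCCc4cccnc42)NC3)C[C@H](C)N1`: 85.6%

In an ADME assay on microsomes from liver (Mus musculus) for metabolic stability, read by LC-MS, with a stated time of 10 min (on this read-out higher numbers stand for a more stable compound and lower numbers for a less stable compound), compound 1 gives 50.8%, the lower of the two numbers seen so far, and compound 2 gives 85.6%. For the measured compounds named here, the only measured step, a number 34.8 percentage points higher from compound 1 to compound 2 (beyond the scatter), exchanges the whole group on the aromatic carbon. Compound 3 `CN(C[C@H]1Cc2c(cccc2N2CCNCC2)CN1)[C@H]1CCCc2cccnc21` has not been measured yet. It differs from compound 1 by hydrogen in place of oxetan-3-yl on an amine nitrogen in a ring; the six-membered non-aromatic ring with 2 nitrogen and the shared core stay as they are in compound 1. Going by the values given here, the step from compound 1 to compound 2 is the only one that touches this part of the molecule, and it was large, but it replaced the full 4-(oxetan-3-yl)piperazin-1-yl by 3,5-dimethylpiperazin-1-yl, a bigger alteration than the one that leads to compound 3. A smaller shift is therefore expected here, more likely upward than downward, as a number 11.2 percentage points higher from compound 1 to compound 3 (beyond the scatter). Compound 3 is expected to give about 62% in this assay, within a range from 38% to 86%.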

Compound 3, percent of the compound remaining: 19.9%
Compound 3: middle estimate off by 42.1 percentage points, on the high side, and the stated range ends above it.
By their numbers in this assay, from the lowest: compound 3; then compound 1; then compound 2.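

In this assay, putting hydrogen in place of oxetan-3-yl on the amine nitrogen in the ring gives a number 30.9 percentage points lower from compound 1 to compound 3 (beyond the scatter), so this substituent alone makes a large difference, and the change does not raise the number as the earlier step might have suggested. The new compound also shows that a free hydrogen on that nitrogen does not by itself go with a low number: compound 2 carries one too, and piperazin-1-yl in place of 3,5-dimethylpiperazin-1-yl gives a number 65.7 percentage points lower from compound 2 to compound 3 (beyond the scatter). Of the three compounds, the one with the unsubstituted piperazin-1-yl therefore stands lowest, and both ways of adding to that ring, on the nitrogen or on its carbons, stand above it; nothing measured here explains why.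

Still open, as far as these compounds go, is whether a small group on the same nitrogen, such as methyl or acetyl, would match the effect of oxetan-3-yl, or whether a longer chain would do as well. From the compounds shown here alone, it is also open whether one methyl on a ring carbon would be enough, or whether both methyl groups of compound 2 are needed to keep its number high.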